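The source may report more compounds than this note shows. Statements on the series, on what has been measured and on what is new or still open speak of the compounds shown alone.

Compound 1 `Cn1c(-c2ccccc2C(F)(F)F)nnc1C12CCC(CCS(C)(=O)=O)(CC1)CC2` is the starting point of this account. In an assay on CHO-K1 cells for inhibition of 11-beta-hydroxysteroid dehydrogenase type 2 (Mus musculus), read by scintillation proximity assay (on this read-out higher numbers stand for weaker inhibition and lower numbers for stronger inhibition), compound 1 gives > 4000 nM, which is a limit of the assay rather than a measured number. Two companions share that standing. Compound 2 `CCS(=O)(=O)CCC12CCC(c3nnc(-c4ccccc4C)n3C)(CC1)CC2` gives > 4000 nM in this assay, again a limit. Compound 3 `CCS(=O)(=O)CCC12CCC(c3nnc(-c4ccccc4Br)n3C)(CC1)CC2` gives > 4000 nM in this assay, likewise a limit. All three values thus sit at the limit of > 4000 nM in this assay, at which 3 of the 3 values shown sit, so compound 1 cannot be ranked against either companion. Going by the values given here, the single measured change, bromo in place of methyl on an aromatic carbon, yields a step that the two limits leave unreadable from compound 2 to compound 3 and gives no readable size or direction.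

Compound 4 `Cn1c(-c2ccccc2C(F)(F)F)nnc1C12CCC(CCCC(C)(F)F)(CC1)CC2` is the untested neighbour; it differs from compound 1 in one place: 2,2-difluoropropyl in place of methylsulfonyl on a saturated chain carbon, two bonds along the chain from a saturated ring carbon. Among the compounds with values here, no measured pair involves a change of this kind, and the one measured step stands unreadable between limits. There is therefore no basis for expecting movement in either direction, and the most plausible outcome is another limit. The step this estimate implies in this assay is a number no higher from compound 1 to compound 4 (the limit leaves the size open). Compound 4 is expected to give 4000 nM in this assay, with a range from 1000 nM to 20000 nM around that estimate.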

Compound 4, half-maximal inhibitory concentration: > 4000 nM
Compound 4 gave a limit, no number; the forecaster's own chance of this, stated with the estimate: 70%; the middle value lies on the limit itself.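

In this assay compound 4 gives > 4000 nM, which is a limit of the assay and not a number. Compound 1 also stands at a limit, so no step can be read between compound 1 and compound 4: the limit of > 4000 nM in this assay, at which 4 of the 4 values shown sit.

The compounds shown leave open how compounds 1 to 4 rank against one another in this assay.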